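Same Methyl Branch Tried on a Second Core

The source may report more compounds than this note shows. Statements on the series, on what has been measured and on what is new or still open speak of the compounds shown alone.

Measured compounds:
- Compound 1 `CCCOC(=O)C1=C(C)NC(=O)NC1c1ccoc1`: 1190 nM
- Compound 2 `CC1=C(C(=O)OCC(C)C)C(c2ccoc2)NC(=O)N1`: 326 nM
- Compound 3 `CCCC(=O)C1=C(C)NC(=O)NC1c1ccco1`: 807 nM

All three were tested in an assay on membranes from HEK293 cells for displacement of a labelled ligand from adenosine receptor A2b (Homo sapiens), read by scintillation counting, with a stated time of 30 min; a lower number here means a stronger inhibitor, a higher number a weaker inhibitor. Compound 1 gives 1190 nM, and its close relative compound 2 gives 326 nM. The two differ only by methyl in place of hydrogen on a saturated chain carbon bound to two saturated chain carbons, and that change brought a 3.7-fold lower number from compound 1 to compound 2 (0.56 log units; beyond the scatter).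

Compound 3 belongs to a different core; the difference between the two cores is not broken down here. In this assay compound 3 gives 807 nM, which sits within the scatter of compound 1 and beyond the scatter of compound 2.

Compound 4 `CC1=C(C(=O)CC(C)C)C(c2ccco2)NC(=O)N1` has not yet been measured. It differs from compound 3 by methyl in place of hydrogen on a saturated chain carbon bound to two saturated chain carbons. This is the same change as the one from compound 1 to compound 2, made on the other core, and it occurs twice among the compounds shown.

If the change repeats its earlier effect, a similar step is expected from compound 3 to compound 4, giving a 2.9-fold lower number from compound 3 to compound 4 (0.46 log units; beyond the scatter); this rests on the single earlier step of a 3.7-fold lower number from compound 1 to compound 2 (0.56 log units; beyond the scatter) and on the starting value of compound 3, 807 nM, while the cores differ and only one example of the change exists. Compound 4 is therefore estimated at 280 nM, with a range from 120 nM to 650 nM.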

Compound 4, inhibition constant: 240 nM
Estimate against measurement, compound 4: 1.2-fold (0.07 log units) above, and the stated range covers the measured number.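

Replacing the propylcarbonyl group of compound 3 with the isobutylcarbonyl group of compound 4 gave a 3.4-fold lower number from compound 3 to compound 4 (0.53 log units; beyond the scatter) in this assay, so the added methyl lowered the number on this second core as well. Set side by side, the two steps match, which means that in this small series the size of the first step was a fair guide to the size of the second: the same change on two cores in this assay, a 3.7-fold lower number (0.56 log units; beyond the scatter) from compound 1 to compound 2 and a 3.4-fold lower number (0.53 log units; beyond the scatter) from compound 3 to compound 4, 1.1-fold (0.04 log units) apart, within the scatter of two such steps

For the compounds shown here, this agreement rests on only two pairs of compounds, so it does not show that the change would carry over in the same way to any further core, and it says nothing about why the added methyl lowers the number or how the two cores compare with each other.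

The compounds shown also leave open how far this trend along the chain extends, for example whether a longer chain or a tert-butyl group would lower the number further or raise it again. Nor do they show what an amine or a carboxylic acid at the end of the chain would do to the number on either core.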